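The compounds below may be only part of what the source reports. "The series", "measured", "known", "first", "only" and "open" are said of these compounds alone.

Measured so far in a functional assay on HT-29 cells (Homo sapiens) for inhibition, read by sulforhodamine B assay, with a stated time of 48 h, tested at 10 uM; on this read-out lower numbers stand for less inhibition and higher numbers for more inhibition at the one concentration tested (going by the name of the read-out):
- compound 1 `c1ccc(-c2cn3ccnc3c(-c3ccc4ncn(C5CCCCC5)c4c3)n2)cc1`: 48.3%
- compound 2 `COc1ccc(-c2cn3ccnc3c(-c3ccc4ncn(C5CCCCC5)c4c3)n2)cc1`: 92.5%
- compound 3 `CC(=O)c1ccc(-c2cn3ccnc3c(-c3ccc4ncn(C5CCCCC5)c4c3)n2)cc1`: 9.2%

Compound 3 stands lowest of the three, beyond the scatter from both others: a number 39.1 percentage points lower from compound 1 to compound 3 (beyond the scatter) and a number 83.3 percentage points lower from compound 2 to compound 3 (beyond the scatter). Compound 4 `Brc1ccc(-c2cn3ccnc3c(-c3ccc4ncn(C5CCCCC5)c4c3)n2)cc1` is not yet measured. It differs from compound 3 as follows: bromo in place of acetyl on an aromatic carbon.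

Among the compounds with values here, the steps that bear on this are the two arriving at the acetyl compound, both large, and the step of a number 44.2 percentage points higher from compound 1 to compound 2 (beyond the scatter), which shows that what sits at this position on the phenyl moves this assay strongly in either direction. Within the data shown here, no bromo compound has been measured, so the direction for compound 4 rests on the acetyl being removed. Since the acetyl compound 3 sits far below the hydrogen compound 1, the step of a number 35.8 percentage points higher from compound 3 to compound 4 (beyond the scatter) is expected to be upward, with wide uncertainty. For compound 4 the estimate is 45%, within 15% to 80%.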

Compound 4, a percentage reported as inhibition, at one concentration (the size of the read-out at that concentration, not a potency): 20.9%
The estimate for compound 4 lay 24.1 percentage points above the measured number; low and high end bracket the measured number.
By their numbers in this assay, from the lowest: compound 3; then compound 4; then compound 1; then compound 2.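

In this assay, bromo at this position falls on the same low side of hydrogen as acetyl, with a number 27.4 percentage points lower from compound 1 to compound 4 (beyond the scatter). Exchanging acetyl for bromo recovers only part of that loss, with a number 11.7 percentage points higher from compound 3 to compound 4 (beyond the scatter). Of the groups compared here, only methoxy stands above hydrogen, and it remains well clear of bromo, with a number 71.6 percentage points lower from compound 2 to compound 4 (beyond the scatter).

Nothing available accounts for these differences. Going by these compounds, whether an amine or a carboxylic acid at this position would reach the methoxy level remains open.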